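This account rests on a few compounds, and the source may have more. Where it says the series, first, only, none or still open, it means among the compounds named here.

Notes on the series. Compound 2 `O[C@H](COCCOC[C@@H](O)Cc1c[nH]nn1)Cc1ccc(-c2ccccc2)cc1` carries a hydrogen on the aromatic nitrogen of its five-membered ring with three nitrogen. In a functional assay on HCT-116 cells (Homo sapiens) for inhibition, read by MTT assay, with a stated time of 72 h (on this read-out higher numbers stand for weaker inhibition of growth and lower numbers for stronger inhibition of growth), compound 2 gives only a limit, > 100000 nM, so no number is known for it. Compound 1 `O[C@H](COCCOC[C@@H](O)Cc1cn(-c2cccs2)nn1)Cc1ccc(-c2ccccc2)cc1` differs by a thiophen-2-yl group on that nitrogen, and in this assay compound 1 gives 33400 nM. The step of an at least 2.9-fold higher number from compound 1 to compound 2 (0.47 log units; beyond the scatter) is the only measured one, and it runs into the limit (the limit of > 100000 nM in this assay, at which 1 of the 2 values shown sits), so its true size is not known beyond being at least modest. Compound 3 `O=c1[nH]c2ccc(-n3cc(C[C@H](O)COCCOC[C@@H](O)Cc4ccc(-c5ccccc5)cc4)nn3)cc2s1` is not yet measured; it differs from compound 2 by a group of 10 heavy atoms (7 carbon, 1 nitrogen, 1 oxygen, 1 sulfur; one five-membered aromatic ring with 2 hetero atoms, one six-membered aromatic ring of carbon only) in place of a hydrogen atom, on an aromatic nitrogen. This runs in the opposite direction to the measured step: a ring group replaces the hydrogen on the aromatic nitrogen, as in compound 1. The expectation in this assay is therefore a lower number for compound 3 than the limit of compound 2, roughly of the size seen on removing the thiophen-2-yl group, that is an at least 4.0-fold lower number from compound 2 to compound 3 (0.60 log units; beyond the scatter). Compound 3 is estimated at 25000 nM, within 6000 nM to 90000 nM. That a measurement again stops at the limit cannot be excluded.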

Compound 3, concentration for 50% growth inhibition: 9200 nM
For compound 3 the middle estimate is 2.7-fold (0.43 log units) above the measured one; measured number inside the range.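

Notes on the result. In this assay, the aromatic nitrogen tolerates a larger ring group than thiophen-2-yl, and the larger group gives a further gain (a 3.6-fold lower number from compound 1 to compound 3 (0.56 log units; beyond the scatter)). With a second ring group now showing a measurable number, the gain over hydrogen is no longer tied to thiophen-2-yl alone. Compound 2 gives only a limit, so the step (an at least 10-fold lower number from compound 2 to compound 3 (1.03 log units; beyond the scatter)) is a bound and not a size: the limit of > 100000 nM in this assay, at which 1 of the 3 values shown sits.

The group in compound 3 differs from thiophen-2-yl in several ways at once, including its heavy-atom count, its six-membered aromatic ring of carbon only and its double bond outside aromatic rings, so the compounds shown do not tell which of these features goes with the lower number. Going by these compounds, it also stays open whether a plain phenyl group on this nitrogen would match compound 3, and whether an amine or a carboxylic acid carried on such a ring, or a methyl group alone on the nitrogen, would keep a measurable number in this assay.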